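Replacing chloro with hydroxy in compound 1

The compounds below may be only part of what the source reports. "The series", "measured", "known", "first", "only" and "open" are said of these compounds alone.

In a functional assay on HCC827 cells (Homo sapiens) for inhibition, read by fluorescence, with a stated time of 72 h (on this read-out higher numbers stand for weaker inhibition of growth and lower numbers for stronger inhibition of growth), compound 1 (`CC(C)CCn1cnc2c(Nc3ccc(Cl)cc3)nc(N[C@H]3CC[C@H](N)CC3)nc21`) gives 10200 nM while compound 2 (`CCCCn1cnc2c(Nc3ccc(Cl)cc3)nc(N[C@H]3CC[C@H](N)CC3)nc21`) gives 10800 nM and compound 3 (`CCCCn1cnc2c(Nc3ccccc3)nc(N[C@H]3CC[C@H](N)CC3)nc21`) gives 9000 nM so compound 1 stands among three numbers that agree within the usual scatter. Compound 4 (`CC(C)CCn1cnc2c(Nc3ccc(O)cc3)nc(N[C@H]3CC[C@H](N)CC3)nc21`) carries hydroxy in place of chloro on an aromatic carbon. The closest evidence is a change at that same carbon, from chloro to hydrogen: a 1.2-fold lower number from compound 2 to compound 3 (0.08 log units; within the scatter) stays within the scatter. A change in the chain, a 1.1-fold higher number from compound 1 to compound 2 (0.02 log units; within the scatter) does the same. Going by the values given here, no measured compound carries hydroxy, so the range is kept wide. No change beyond the scatter is therefore expected in this assay and a 1.1-fold lower number from compound 1 to compound 4 (0.05 log units; within the scatter) is the estimated step. Compound 4 is expected at 9000 nM with 3500 nM to 20000 nM as the estimated range.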

Compound 4, concentration for 50% growth inhibition: 14400 nM
Compound 4: middle estimate off by 1.6-fold (0.20 log units), on the low side, within the range that was stated.
By their numbers in this assay, from the lowest: compounds 3, 1, 2 and 4 (each within the scatter of the next).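

In this assay, going by these compounds alone, the earlier compounds showed only chloro and hydrogen on this aromatic carbon. Hydroxy in place of chloro gives a 1.4-fold higher number from compound 1 to compound 4 (0.15 log units; within the scatter), so even a group counted as a hydrogen-bond donor and acceptor, unlike chloro, leaves the growth-inhibition number within the scatter. No measurement shown gives a reason for this result. From the compounds shown here alone, whether an amine, a methoxy or a carboxylic acid on this carbon would also stay within the scatter remains open. So does whether hydroxy would give a similar step with the chain of compound 2.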